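The source may hold more compounds than are shown below. What is called first, only, known or untested is meant among the compounds shown, and "the series" means these compounds.

Among the compounds with values here, compound 2 `COc1ccc(N2C(=O)[C@H]3[C@H](ON4[C@@H]3C(=O)N(C)[C@@]43C[C@H](C)CC[C@H]3C(C)C)C2=O)cc1` gives 48.1% in a functional assay, with a stated time of 20 min, tested at 1 mg/mL (a higher number here means a stronger effect of the compound at the concentration tested, a lower number a weaker effect), and stands highest of the two numbers measured so far, while compound 1 `CC(C)[C@@H]1CC[C@@H](C)C[C@@]12N(C)C(=O)[C@@H]1[C@H]3C(=O)N(c4ccc(Cl)cc4)C(=O)[C@H]3ON12` gives 31.7%. Within the data shown here, the only measured step, a number 16.4 percentage points higher from compound 1 to compound 2 (beyond the scatter), shows that the group on the amide-type nitrogen in a ring can shift this assay by a modest amount. Compound 3 `Cc1cccc(N2C(=O)[C@H]3[C@H](ON4[C@@H]3C(=O)N(C)[C@@]43C[C@H](C)CC[C@H]3C(C)C)C2=O)c1` differs from compound 2 in this way: 3-methylphenyl in place of 4-methoxyphenyl on an amide-type nitrogen in a ring. Among the measured compounds shown here, no measured step covers a 3-methylphenyl there, so that single step guides the expectation only loosely. A small drop, or no change beyond the scatter, is expected, a number 10.1 percentage points lower from compound 2 to compound 3 (beyond the scatter). Compound 3 is estimated to give 38%, within 20% to 56%.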

Compound 3, a percentage reported as activity, at one concentration (the size of the read-out at that concentration, not a potency): 38.7%
Beside the measured number, compound 3's estimate is 0.7 percentage points below it; the range from low to high includes it.
By their numbers in this assay, from the lowest: compounds 1, 3 and 2 (each within the scatter of the next, the first and the last beyond it).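

In this assay, putting 3-methylphenyl in place of 4-methoxyphenyl gives a number 9.4 percentage points lower from compound 2 to compound 3 (within the scatter), and putting it in place of 4-chlorophenyl gives a number 7 percentage points higher from compound 1 to compound 3 (within the scatter). On this amide-type nitrogen, 3-methylphenyl therefore cannot be told apart from either earlier group, although those two groups do differ from each other beyond the scatter. Nothing available explains these numbers. On these data alone, it remains open whether an amine or a carboxylic acid on the phenyl ring, or a longer chain replacing that ring, would move this read-out further.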